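The compounds below may be only part of what the source reports. "The series", "measured", "known", "first", "only" and "open" are said of these compounds alone.

Measured compounds:
- Compound 1, `CCOC(=O)c1cnc(N(C(C)=O)N2C(=O)C=C(C)C2=O)nc1C(F)(F)F`, in a functional assay on Jurkat cells (Homo sapiens) for inhibition (a lower number here means a stronger inhibitor, a higher number a weaker inhibitor), compound 1 gives 410 nM.
- Compound 2, `CCOC(=O)c1cnc(NN2C(=O)C=C(C)C2=O)nc1C(F)(F)C(F)(F)F`, in this assay compound 2 gives 200 nM.

Compound 2 has the lower of the two numbers, and the gap to compound 1 lies beyond the usual scatter; the two compounds differ in more than one place, so only the two values themselves can be compared. Compound 3, `CCOC(=O)c1cnc(NN2C(=O)C=C(C)C2=O)nc1-c1cc2ccccc2s1`, is not yet measured. It differs from compound 2 in one place: 1-benzothiophen-2-yl in place of 1,1,2,2,2-pentafluoroethyl on an aromatic carbon. For the measured compounds named here, no measured pair shows the effect of this exchange, so the expectation rests on compound 2 alone, whose value of 200 nM is the starting point. The replacement is large, and the author expects a step from compound 2 to compound 3 of a 2.0-fold higher number from compound 2 to compound 3 (0.30 log units; within the scatter), weakly toward a higher number and within or close to the scatter. Compound 3 is therefore estimated at 400 nM, with a range from 80 nM to 2000 nM.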

Compound 3, half-maximal inhibitory concentration: 800 nM
For compound 3 the middle estimate is 2.0-fold (0.30 log units) below the measured one; measured number inside the range.
By their numbers in this assay, from the lowest: compound 2; then compounds 1 and 3 (each within the scatter of the next).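

In this assay, for the compounds shown here, 1-benzothiophen-2-yl in place of 1,1,2,2,2-pentafluoroethyl gives a 4.0-fold higher number from compound 2 to compound 3 (0.60 log units; beyond the scatter), the first reading of a single exchange at this position. The position, on an aromatic carbon next to the ring nitrogen and ortho to an ethoxycarbonyl group, is therefore not indifferent to its substituent, yet it accepts a group with two aromatic rings, since compound 3 still gives 800 nM. Nothing available explains the size or direction of this step.

The compounds shown leave open whether a phenyl, a thiophen-2-yl or a methyl group at this position would stand closer to compound 2 or to compound 3. From the compounds shown here alone, it also remains open whether the exchange would have the same effect with an acetyl group on the linking nitrogen, as in compound 1.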